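The source may report more compounds than this note shows. Statements on the series, on what has been measured and on what is new or still open speak of the compounds shown alone.

Compound 2, `Cc1c(Cc2cccnc2)c2cc(CCC(=O)O)ccc2n1CCNS(=O)(=O)c1ccc(F)cc1`, gives 61 nM in an assay with Thromboxane-A synthase (Homo sapiens) as the target, using microsomes; on this read-out lower numbers stand for stronger inhibition and higher numbers for weaker inhibition; that is the higher of the two numbers measured, though compound 1, `Cc1c(Cn2ccnc2)c2cc(CCC(=O)O)ccc2n1CCNS(=O)(=O)c1ccc(F)cc1`, with 39 nM sits within the scatter of it, since a 1.6-fold higher number from compound 1 to compound 2 (0.19 log units; within the scatter). Compound 3, `Cc1c(Cc2ccncc2)c2cc(CCC(=O)O)ccc2n1CCNS(=O)(=O)c1ccc(F)cc1`, differs from compound 2 by pyridin-4-yl in place of pyridin-3-yl on a saturated chain carbon bound to an aromatic carbon. Among the compounds with values here, no measured step exchanges one pyridinyl for another; the only step at this position, from compound 1 to compound 2, stayed within the scatter, so nothing points to a change beyond the scatter. Compound 3 is therefore expected to give about 90 nM, between 25 nM and 400 nM, a step of a 1.5-fold higher number from compound 2 to compound 3 (0.17 log units; within the scatter).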

Compound 3, half-maximal inhibitory concentration: 78 nM
For compound 3 the middle estimate is 1.2-fold (0.06 log units) above the measured one, and the stated range covers the measured number.
By their numbers in this assay, from the lowest: compounds 1, 2 and 3 (each within the scatter of the next).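

Exchanging pyridin-3-yl for pyridin-4-yl on a saturated chain carbon bound to an aromatic carbon gives a 1.3-fold higher number from compound 2 to compound 3 (0.11 log units; within the scatter), so this first comparison of two pyridinyl groups does not tell them apart. Comparing pyridin-4-yl with 1H-imidazol-1-yl gives a 2.0-fold higher number from compound 1 to compound 3 (0.30 log units; within the scatter), so all three rings at this position read alike within the scatter. Nothing available explains this similarity.

Still open, from the compounds shown here alone, is whether pyridin-2-yl or a plain phenyl ring would read the same here. Going by these compounds, a longer chain linking the ring to the shared core is equally open.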